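The compounds below may be only part of what the source reports. "The series", "measured", "known", "first", "only" and "open" are said of these compounds alone.

Compound 1 `C=CC1=C(C(=O)NCCC)C(c2ccc(F)cc2)OC1` and compound 3 `C=CC1=C(C(=O)NCCC)C(c2ccc(OC)c(OC)c2)OC1` both carry an amide bearing a propyl group; the difference between their two cores is not broken down here. In a functional assay on QGY7701 cells (Homo sapiens) for cytotoxicity, read by MTT assay, with a stated time of 24 h (a higher number here means a weaker inhibitor, a lower number a stronger inhibitor), compound 1 gives only a limit of the assay, > 100000 nM. Compound 3 likewise gives only a limit in this assay, > 100000 nM. Compound 2 `C=CC1=C(C(=O)NCc2ccc(C)cc2)C(c2ccc(F)cc2)OC1` differs from compound 1 by 4-methylphenyl in place of ethyl on a saturated chain carbon bound to an amide-type nitrogen. In this assay compound 2 gives 62100 nM, which is an at least 1.6-fold lower number from compound 1 to compound 2 (0.20 log units; that floor lies within the scatter). Only the floor of this step is known, because it starts from the limit of > 100000 nM in this assay, at which 2 of the 3 values shown sit. Compound 4 `C=CC1=C(C(=O)NCc2ccc(C)cc2)C(c2ccc(OC)c(OC)c2)OC1` applies the same change to compound 3, (4-methylphenyl in place of ethyl on a saturated chain carbon bound to an amide-type nitrogen). The expected step here is an at least 1.4-fold lower number from compound 3 to compound 4 (0.15 log units; that floor lies within the scatter), resting on compound 2 having moved off the limit shown by an at least 1.6-fold lower number from compound 1 to compound 2 (0.20 log units; that floor lies within the scatter), while the starting point at the limit of > 100000 nM in this assay, at which 2 of the 3 values shown sit, leaves a fair chance that compound 4 also returns only a limit. Compound 4 is therefore estimated at 70000 nM in this assay, with an expected range between 30000 nM and 150000 nM.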

Compound 4, half-maximal inhibitory concentration: 69100 nM
Estimate against measurement, compound 4: 1.0-fold (0.01 log units) above; low and high end bracket the measured number.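

In this assay, 4-methylphenyl in place of ethyl on a saturated chain carbon bound to an amide-type nitrogen gives an at least 1.4-fold lower number from compound 3 to compound 4 (0.16 log units; that floor lies within the scatter). Carried to this second core, the change again leads from a propyl amide at the limit of the assay to a 4-methylbenzyl amide with a measured number, and the two steps compare as follows: the same change on two cores in this assay, an at least 1.6-fold lower number (0.20 log units; that floor lies within the scatter) from compound 1 to compound 2 and an at least 1.4-fold lower number (0.16 log units; that floor lies within the scatter) from compound 3 to compound 4; the limit leaves it open whether they differ. This shows that the outcome recurs on both cores, but it does not show a true size for either step or that the change acts equally on them, because both starting points are limits rather than numbers: the limit of > 100000 nM in this assay, at which 2 of the 4 values shown sit.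

The compounds shown leave open whether the methyl group on the ring matters, since a plain benzyl group does not appear among them. They also leave open how the amide would respond to a longer chain, or to a benzyl group carrying an amine or a carboxylic acid.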